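Changing the Aromatic Group on the Ring Nitrogen

The source may hold more compounds than are shown below. What is called first, only, known or untested is meant among the compounds shown, and "the series" means these compounds.

Three compounds share one core and differ only in the aromatic group attached to a ring nitrogen. Compound 1 `CCOC(=O)c1c(-c2c(Cl)c3ccccc3oc2=O)nn(-c2cccc(C)c2)c1C(=O)OCC` carries a 3-methylphenyl group; in a functional assay on DU-145 cells (Homo sapiens) for cytotoxicity, read by MTT assay, with a stated time of 48 h (on this read-out lower numbers stand for stronger inhibition and higher numbers for weaker inhibition), compound 1 gives 32000 nM. Compound 2 `CCOC(=O)c1c(-c2c(Cl)c3ccccc3oc2=O)nn(-c2ccc(OC)cc2)c1C(=O)OCC` carries a 4-methoxyphenyl group, and in this assay compound 2 gives 25000 nM. Compound 3 `CCOC(=O)c1c(-c2c(Cl)c3ccccc3oc2=O)nn(-c2cccc(Cl)c2)c1C(=O)OCC` carries a 3-chlorophenyl group, and in this assay compound 3 gives 24000 nM. These three numbers sit close together: a 1.3-fold lower number from compound 1 to compound 2 (0.11 log units; within the scatter), a 1.3-fold lower number from compound 1 to compound 3 (0.12 log units; within the scatter) and a 1.0-fold lower number from compound 2 to compound 3 (0.02 log units; within the scatter). Compound 3 thus has the lowest of the three numbers, but it lies within the scatter of both others, so no order among them can be claimed.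

Compound 4 `CCOC(=O)c1c(-c2c(Cl)c3ccccc3oc2=O)nn(-c2ccc(Br)cc2)c1C(=O)OCC` differs from compound 3 in one place: 4-bromophenyl in place of 3-chlorophenyl on an aromatic nitrogen. Every measured step exchanges one aromatic group on this nitrogen for another, and none of them moved the number beyond the scatter. The exchange of a 3-chlorophenyl for a 4-bromophenyl group is of the same kind, so for compound 4 no step beyond the scatter is expected in this assay; the expected step is a 1.0-fold higher number from compound 3 to compound 4 (0.02 log units; within the scatter). Compound 4 is therefore estimated at 25000 nM, with a range from 12000 nM to 50000 nM.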

Compound 4, half-maximal inhibitory concentration: 32000 nM
The estimate for compound 4 lay 1.3-fold (0.11 log units) below the measured number, within the range that was stated.
By their numbers in this assay, from the lowest: compounds 3, 2, 1 and 4 (each within the scatter of the next).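

In this assay, 4-bromophenyl in place of 3-chlorophenyl alters both the halogen and where it sits on the phenyl ring, yet it gives a 1.3-fold higher number from compound 3 to compound 4 (0.12 log units; within the scatter), so even this double change leaves the number within the scatter. Bromo in place of methoxy gives a 1.3-fold higher number from compound 2 to compound 4 (0.11 log units; within the scatter), and 4-bromophenyl in place of 3-methylphenyl gives no change at the digits printed from compound 1 to compound 4 (within the scatter), so the methyl, methoxy, chloro and bromo versions of this aromatic group cannot be told apart in this assay. Nothing measured explains why these exchanges leave the number so flat.

The compounds shown leave open how this nitrogen would respond to something other than a phenyl ring with one small substituent, such as a phenyl ring bearing an amine or a carboxylic acid, or a plain alkyl chain in place of the ring. Going by these compounds, the two ethoxycarbonyl groups and the rest of the shared core stay the same throughout, so it also remains open whether a change there, for example a carboxylic acid in place of an ethoxycarbonyl group, would move the number beyond the scatter.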